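Changing the Aryl Group on the Amine Nitrogen

The compounds below may be only part of what the source reports. "The series", "measured", "known", "first", "only" and "open" are said of these compounds alone.

Compound 1 `CCS(=O)(=O)Nc1cc(-c2ccc3ncnc(Nc4ccc(F)cc4F)c3c2)cnc1OC` carries a 2,4-difluorophenyl group on a nitrogen on an aromatic ring of the shared core. In a functional assay on BT-549 cells (Homo sapiens) for cytotoxicity, read by sulforhodamine B assay, with a stated time of 72 h (on this read-out lower numbers stand for stronger inhibition and higher numbers for weaker inhibition), compound 1 gives 2480 nM, the lowest of the three numbers recorded, though the gaps to the other two are small. Compound 2 `CCS(=O)(=O)Nc1cc(-c2ccc3ncnc(Nc4ccc(OC)c(OC)c4)c3c2)cnc1OC` gives 2590 nM and compound 3 `CCS(=O)(=O)Nc1cc(-c2ccc3ncnc(Nc4ccc(F)c(C(=O)OC)c4)c3c2)cnc1OC` gives 2740 nM. The change from compound 1 to compound 2 is a 1.0-fold higher number from compound 1 to compound 2 (0.02 log units; within the scatter), that from compound 1 to compound 3 is a 1.1-fold higher number from compound 1 to compound 3 (0.04 log units; within the scatter), and that from compound 2 to compound 3 is a 1.1-fold higher number from compound 2 to compound 3 (0.02 log units; within the scatter); all three steps are within the scatter, so the three aryl groups cannot be told apart on this read-out.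

Compound 4 `CCS(=O)(=O)Nc1cc(-c2ccc3ncnc(Nc4ccc(OC)nc4)c3c2)cnc1OC` is not yet measured. It differs from compound 1 as follows: 6-methoxypyridin-3-yl in place of 2,4-difluorophenyl on a nitrogen on an aromatic ring. Going by the values given here, the steps that bear on it are the two exchanges of the same aryl group starting from compound 1, a 1.0-fold higher number from compound 1 to compound 2 (0.02 log units; within the scatter) and a 1.1-fold higher number from compound 1 to compound 3 (0.04 log units; within the scatter), neither of which moved the number beyond the scatter. Nothing in the measured set suggests that a 6-methoxypyridin-3-yl group in place of 2,4-difluorophenyl would read differently, so the expected step of a 1.0-fold higher number from compound 1 to compound 4 (0.02 log units; within the scatter) is none beyond the scatter. Compound 4 is therefore estimated at 2600 nM in this assay, within a range of 1300 nM to 5200 nM.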

Compound 4, half-maximal inhibitory concentration: 3490 nM
Beside the measured number, compound 4's estimate is 1.3-fold (0.13 log units) below it; the range from low to high includes it.
By their numbers in this assay, from the lowest: compounds 1, 2, 3 and 4 (each within the scatter of the next).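

Going by these compounds alone, compound 4 brings a six-membered aromatic ring with a hetero atom onto the amine nitrogen, where the earlier compounds carried rings of carbon only. In this assay, this exchange gives a 1.4-fold higher number from compound 1 to compound 4 (0.15 log units; within the scatter), while the comparisons with the other two aryl groups give a 1.3-fold higher number from compound 2 to compound 4 (0.13 log units; within the scatter) and a 1.3-fold higher number from compound 3 to compound 4 (0.11 log units; within the scatter). The position therefore accepts the 6-methoxypyridin-3-yl group as well, and all four aryl groups remain indistinguishable on this read-out, while no further measurement bears on what lies behind these numbers.

As far as these compounds go, all four compounds hold a six-membered aromatic ring at this nitrogen, so it stays open whether a cyclohexyl ring, a longer alkyl chain, or an aryl ring carrying a carboxylic acid or an amine would move the number beyond the scatter. From the compounds shown here alone, since the four compounds differ only in this one place, it also stays open whether a change elsewhere on the shared core would leave the number as unmoved as these exchanges did.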